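Triazole N-substituent variants of the bis-hydroxy ether core

This account rests on a few compounds, and the source may have more. Where it says the series, first, only, none or still open, it means among the compounds named here.

Measured compounds:
compound 1 `O[C@H](COCCOC[C@@H](O)Cc1cn(Cc2ccc(Oc3ccccc3)cc2)nn1)Cc1ccc(-c2ccccc2)cc1` — 4500 nM
compound 2 `O[C@H](COCCOC[C@@H](O)Cc1cn(-c2cccs2)nn1)Cc1ccc(-c2ccccc2)cc1` — 33400 nM

In a functional assay on SGC-7901 cells (Homo sapiens) for inhibition, read by MTT assay, with a stated time of 72 h (on this read-out higher numbers stand for weaker inhibition of growth and lower numbers for stronger inhibition of growth), compound 1 gives 4500 nM, while compound 2 gives 33400 nM. Compound 2 thus stands at the higher end of the two numbers, and its gap to compound 1 lies beyond the usual scatter. The two differ in the group attached to the aromatic nitrogen of the shared core: a phenoxy-substituted benzyl in compound 1 against a thiophen-2-yl attached directly in compound 2.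

Compound 3 `O[C@H](COCCOC[C@@H](O)Cc1cn(-c2ccc3c(c2)OCCO3)nn1)Cc1ccc(-c2ccccc2)cc1` has not been measured. It differs from compound 2 by 2,3-dihydro-1,4-benzodioxin-6-yl in place of thiophen-2-yl on an aromatic nitrogen. Within the data shown here, as in compound 2, the aromatic group is joined directly to the ring nitrogen, so compound 2 is the closer reference; no step between measured compounds covers this change. The expectation is a move in this assay toward somewhat stronger inhibition, but not clearly beyond the scatter around compound 2, so the step of a 1.9-fold lower number from compound 2 to compound 3 (0.27 log units; within the scatter) is estimated to be modest. Compound 3 is estimated at 18000 nM, with a range from 5000 nM to 50000 nM.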

Compound 3, concentration for 50% growth inhibition: 6400 nM
Estimate against measurement, compound 3: 2.8-fold (0.45 log units) above; the measured number falls inside the stated range.
By their numbers in this assay, from the lowest: compounds 1 and 3 (each within the scatter of the next); then compound 2.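

In this assay, the group on the aromatic nitrogen changes the read-out even when the aromatic group stays directly joined to the ring nitrogen: 2,3-dihydro-1,4-benzodioxin-6-yl in place of thiophen-2-yl gives a 5.2-fold lower number from compound 2 to compound 3 (0.72 log units; beyond the scatter). The earlier pair changed both the aromatic group and its attachment, whereas compound 3 keeps the direct attachment and gives 6400 nM, within the scatter of compound 1 at 4500 nM, so among these compounds the phenoxy-substituted benzyl of compound 1 is not the only group that reaches this level. No measurement at hand accounts for the step from thiophen-2-yl to 2,3-dihydro-1,4-benzodioxin-6-yl.

The compounds shown leave open whether the step follows the six-membered aromatic ring alone or also needs the oxygen-containing ring, a question that a plain phenyl on the same nitrogen would address. Also open, going by these compounds, are the effects of a methylene link between the triazole nitrogen and the 2,3-dihydro-1,4-benzodioxin-6-yl group, and of an amine or a carboxylic acid on the directly attached aromatic ring.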